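Hydrogen for fluoro: from compound 3 to compound 4

This account rests on a few compounds, and the source may have more. Where it says the series, first, only, none or still open, it means among the compounds named here.

In a functional assay on CCRF-CEM cells (Homo sapiens) for cytotoxicity, in the presence of a further agent that is not named here (a lower number here means a stronger inhibitor, a higher number a weaker inhibitor), compound 1 `CC(C)(C)OC(=O)CCC(Nc1ccc(CN(CCCc2c(N)nc(N)nc2O)c2cc(F)c([N+](=O)[O-])cc2[N+](=O)[O-])cc1)C(=O)OC(C)(C)C` gives 1800 nM and compound 2 `COC(=O)c1ccc(CN(CCCc2c(N)nc(N)nc2O)c2cc(F)c(F)cc2[N+](=O)[O-])cc1` gives 53000 nM. Compound 3 `Nc1nc(N)c(CCCN(Cc2ccc(NC(CCC(=O)O)C(=O)O)cc2)c2cc(F)c(F)cc2[N+](=O)[O-])c(O)n1` reads > 100000 nM, which is a limit and not a number: the limit of > 100000 nM in this assay, at which 1 of the 3 values shown sits.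

Compound 4 `Nc1nc(N)c(CCCN(Cc2ccc(NC(CCC(=O)O)C(=O)O)cc2)c2cc(F)ccc2[N+](=O)[O-])c(O)n1` carries hydrogen in place of fluoro on an aromatic carbon, taking 4,5-difluoro-2-nitrophenyl to 5-fluoro-2-nitrophenyl. Within the data shown here, no measured step covers this change. Among the measured compounds shown here, the only step available, an at least 1.8-fold higher number from compound 2 to compound 3 (0.27 log units; that floor lies within the scatter), is (1,3-dicarboxypropyl)amino in place of methoxycarbonyl, so it gives no size here. The estimated step is a number no higher from compound 3 to compound 4 (the limit leaves the size open), so no shift beyond the scatter is expected in this assay. Compound 4 is expected at 100000 nM, with an estimated range of 30000 nM to 300000 nM, and another limit is likely.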

Compound 4, half-maximal inhibitory concentration: > 100000 nM
Compound 4: no number, only a limit (the forecaster's own chance of this, stated with the estimate: 65%); the middle value lies on the limit itself.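

Among these compounds, compound 3 and compound 4 both give only a limit, and no step between them can be read. The compounds shown leave open how far hydrogen in place of fluoro on an aromatic carbon moves the read-out, if at all.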